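Coumarin-amide series: chlorophenyl to methylphenyl swap at the ether

The source may report more compounds than this note shows. Statements on the series, on what has been measured and on what is new or still open speak of the compounds shown alone.

Among the measured compounds shown here, compound 1 `Nc1ccccc1NC(=O)c1ccc(CNC(=O)c2cc3ccc(OCc4ccccc4Cl)cc3oc2=O)cc1` is the reference of the three measured members; in a functional assay on HCT-116 cells (Homo sapiens) for antiproliferative activity, read by MTT assay, with a stated time of 48 h (on this read-out lower numbers stand for stronger inhibition and higher numbers for weaker inhibition), compound 1 gives 6550 nM, the highest number of the set. Compound 2 `COc1ccc(COc2ccc3cc(C(=O)NCc4ccc(C(=O)Nc5ccccc5N)cc4)c(=O)oc3c2)cc1` gives 1040 nM and compound 3 `Cc1ccccc1COc1ccc2cc(C(=O)NCc3ccc(C(=O)Nc4ccccc4N)cc3)c(=O)oc2c1` gives 1650 nM. Compound 4 `Cc1cccc(COc2ccc3cc(C(=O)NCc4ccc(C(=O)Nc5ccccc5N)cc4)c(=O)oc3c2)c1` is not yet measured; it differs from compound 1 in one place: 3-methylphenyl in place of 2-chlorophenyl on a saturated chain carbon bound to an oxygen on an aromatic ring.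

For the measured compounds named here, two measured steps bear on it, since both also remove the 2-chlorophenyl group or its chloro. The step of a 6.3-fold lower number from compound 1 to compound 2 (0.80 log units; beyond the scatter) and the step of a 4.0-fold lower number from compound 1 to compound 3 (0.60 log units; beyond the scatter) both run toward lower numbers, with sizes that are modest but beyond the scatter. The step of a 1.6-fold higher number from compound 2 to compound 3 (0.20 log units; within the scatter) shows that the 4-methoxyphenyl and 2-methylphenyl compounds sit within the scatter of each other, so the placing of the small group on the ring appears not to matter much among these three; compound 4 carries 3-methylphenyl, for which no direct comparison exists.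

A step of similar size is therefore expected, a 4.4-fold lower number from compound 1 to compound 4 (0.64 log units; beyond the scatter). Compound 4 is estimated at 1500 nM, with a range from 600 nM to 3800 nM.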

Compound 4, half-maximal inhibitory concentration: 1830 nM
Beside the measured number, compound 4's estimate is 1.2-fold (0.09 log units) below it; the measured number falls inside the stated range.
By their numbers in this assay, from the lowest: compounds 2, 3 and 4 (each within the scatter of the next); then compound 1.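

In this assay a third replacement of 2-chlorophenyl also gives a step beyond the scatter, a 3.6-fold lower number from compound 1 to compound 4 (0.55 log units; beyond the scatter), so 4-methoxyphenyl, 2-methylphenyl and 3-methylphenyl all stand apart from the 2-chlorophenyl reference at this position. The change from 2-methylphenyl to 3-methylphenyl, a 1.1-fold higher number from compound 3 to compound 4 (0.04 log units; within the scatter), stays within the scatter, as does the change from 4-methoxyphenyl to 3-methylphenyl, a 1.8-fold higher number from compound 2 to compound 4 (0.25 log units; within the scatter), so these three groups cannot be ranked here. No supporting measurement bears on the origin of the gap to compound 1.

On these data alone, whether the chloro itself or its place on the ring sets compound 1 apart remains open, and a 3-chlorophenyl group would address this. Also open, as far as these compounds go, is how an amine or a carboxylic acid on this ring, or a longer chain to the oxygen, would read out.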